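Swapping the aryl propyl for a methoxymethyl group

The source may hold more compounds than are shown below. What is called first, only, known or untested is meant among the compounds shown, and "the series" means these compounds.

Compound 2 `CCCc1cccc(C[C@H](O)/C=C/[C@H]2CSC(=O)N2CCSCCCC(=O)O)c1` holds the lower of the two numbers recorded so far in a functional assay on CHO cells for agonist activity at prostaglandin E2 receptor EP4 subtype (Rattus norvegicus), read by cAMP accumulation and immunoassay, with a stated time of 10 min; a higher number here means that more compound is needed for the effect, a lower number that less compound is needed: compound 2 gives 6.1 nM, while compound 1 `CCCc1cccc(C[C@H](O)/C=C/[C@H]2CCC(=S)N2CCCCCCC(=O)O)c1` gives 27 nM, a gap beyond the usual scatter. Compound 3 `COCc1cccc(C[C@H](O)/C=C/[C@H]2CSC(=O)N2CCSCCCC(=O)O)c1` is not yet measured; it differs from compound 2 by methoxy in place of ethyl on a saturated chain carbon bound to an aromatic carbon. For the measured compounds named here, no measured pair shows this change, so the step is expected to be modest, perhaps a small loss of potency. The estimate for compound 3 in this assay is 12 nM, with a range from 4 nM to 40 nM, meaning an expected step of a 2.0-fold higher number from compound 2 to compound 3 (0.29 log units; within the scatter).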

Compound 3, half-maximal effective concentration: 2.4 nM
Estimate against measurement, compound 3: 5.0-fold (0.70 log units) above, outside the stated range (below it).
By their numbers in this assay, from the lowest: compound 3; then compound 2; then compound 1.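

In this assay the change from 3-propylphenyl to 3-(methoxymethyl)phenyl gives a 2.5-fold lower number from compound 2 to compound 3 (0.41 log units; beyond the scatter) and so makes compound 3 the lowest of the three numbers. This place on the saturated chain carbon bound to an aromatic carbon therefore accepts an oxygen, and the result is a gain rather than a loss, with the heavy-atom count unchanged. No measurement available here accounts for this gain.

From the compounds shown here alone, whether an amine, a hydroxyl or a longer ether chain would hold this number remains open. So does whether methoxymethyl would bring a similar step on the core of compound 1.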